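The source may report more compounds than this note shows. Statements on the series, on what has been measured and on what is new or still open speak of the compounds shown alone.

Compound 1 `Fc1ccc(COC(CCn2cncn2)c2ccco2)c(F)c1`: "not determined" (no result reported)
Compound 2 `Fc1ccc(F)c(COC(CCn2ccnc2)c2cccs2)c1`: 15100 nM
Compound 3 `Clc1cccc(COC(CCn2cncn2)c2ccco2)c1`: 18600 nM

For the measured compounds named here, in an ADME assay on J774.A1 cells (Mus musculus) for cytotoxicity, read by MTT assay, with a stated time of 72 h (a higher number here means that more compound is tolerated, a lower number that less compound is tolerated), compound 3 gives 18600 nM and lies within the scatter of compound 2 (15100 nM), the only other number, since compound 1 has no result.

The change to compound 4 `Clc1cccc(COC(CCn2ccnc2)c2ccco2)c1` is 1H-imidazol-1-yl in place of 1H-1,2,4-triazol-1-yl on a saturated chain carbon, three bonds along the chain from an aromatic carbon and an oxygen on a saturated carbon on a saturated chain carbon, three bonds along the chain from an aromatic carbon and an oxygen on a saturated carbon. Going by the values given here, no measured pair shows this change alone. Compound 2 also carries 1H-imidazol-1-yl and gives 15100 nM in this assay but differs from compound 3 elsewhere too.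

No step beyond the scatter is therefore expected: the estimated change is a 1.2-fold lower number from compound 3 to compound 4 (0.09 log units; within the scatter) in this read-out. For compound 4 the estimate is 15000 nM with an expected range of 7000 nM to 30000 nM around it.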

Compound 4, half-maximal cytotoxic concentration: 60200 nM
For compound 4 the middle estimate is 4.0-fold (0.60 log units) below the measured one, outside the stated range (above it).
By their numbers in this assay, from the lowest: compounds 2 and 3 (each within the scatter of the next); then compound 4.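

In this assay, putting 1H-imidazol-1-yl in place of 1H-1,2,4-triazol-1-yl on the saturated chain carbon gives a 3.2-fold higher number from compound 3 to compound 4 (0.51 log units; beyond the scatter) with the rest of the molecule unchanged. For the compounds shown here, this is the first clean comparison at this position, and it shows that the choice of five-membered ring alone can shift how much compound the cells tolerate. Nothing measured here explains why.

Going by these compounds, this rests on a single pair, so it remains open whether the same swap does the same with other groups elsewhere on the molecule. On these data alone, how an amine or a carboxylic acid at this position, or a longer chain leading to the ring, would compare also remains open.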